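The source may report more compounds than this note shows. Statements on the series, on what has been measured and on what is new or still open speak of the compounds shown alone.

Measured in a functional assay on A-431 cells (Homo sapiens) for antiproliferative activity, read by CCK-8 assay, with a stated time of 72 h; on this read-out higher numbers stand for weaker inhibition and lower numbers for stronger inhibition:
- Compound 1 `C#Cc1cccc(Nc2ncnc3cc(OCCOC(=O)c4ccccc4OC(C)=O)c(OCCOC)cc23)c1`: 1800 nM
- Compound 2 `C#Cc1cccc(Nc2ncnc3cc(OCCOC(=O)c4ccccc4OC(C)=O)c(OCCOC(=O)c4ccccc4OC(C)=O)cc23)c1`: > 10000 nM
- Compound 3 `C#Cc1cccc(Nc2ncnc3cc(OCCOC(=O)Cc4c(C)n(C(=O)c5ccc(Cl)cc5)c5ccc(OC)cc45)c(OCCOC(=O)Cc4c(C)n(C(=O)c5ccc(Cl)cc5)c5ccc(OC)cc45)cc23)c1`: > 10000 nM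

Compound 2 gives no number, only the limit > 10000 nM. The same is true of compound 3, as the limit of > 10000 nM in this assay, at which 2 of the 3 values shown sit, shows. Compound 4 `C#Cc1cccc(Nc2ncnc3cc(OCCOC)c(OCCOC(=O)c4ccccc4OC(C)=O)cc23)c1` follows from compound 2 by methyl in place of (2-acetoxyphenyl)carbonyl on an oxygen on a saturated carbon, with methyl in place of (2-acetoxyphenyl)carbonyl on an oxygen on a saturated carbon. Going by the values given here, one measured step bears on this: an at least 5.5-fold higher number from compound 1 to compound 2 (0.74 log units; beyond the scatter), the same exchange run the opposite way on the other chain. A step of similar size towards a lower number is therefore expected in this assay, with compound 1 at 1800 nM as the closest guide. The estimated change is an at least 5.0-fold lower number from compound 2 to compound 4 (0.69 log units; beyond the scatter). For compound 4 the estimate is 2000 nM, with an expected range of 600 nM to 7000 nM.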

Compound 4, half-maximal inhibitory concentration: > 10000 nM
Compound 4: only a limit was reported; the forecaster's own chance of this, stated with the estimate: 15%; at least 5.0-fold (0.69 log units) between middle value and limit.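

In this assay compound 4 gives only a limit, > 10000 nM. Going by these compounds alone, compound 2 is also given only as a limit, so no step between compound 2 and compound 4 can be read: the limit of > 10000 nM in this assay, at which 3 of the 4 values shown sit. The compounds shown leave open whether methyl or (2-acetoxyphenyl)carbonyl on that oxygen gives the lower number.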